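Working notes: from compound 2 to compound 3

This account rests on a few compounds, and the source may have more. Where it says the series, first, only, none or still open, it means among the compounds named here.

In a functional assay on MDA-MB-231 cells (Homo sapiens) for inhibition, read by MTT assay, with a stated time of 96 h (on this read-out lower numbers stand for stronger inhibition of growth and higher numbers for weaker inhibition of growth), compound 1 (`O=C(NCCCCCCSSCCCCCCNC(=O)c1cc(-c2ccncc2)n[nH]1)c1cc(-c2ccncc2)n[nH]1`) gives 27300 nM and compound 2 (`O=C(OCc1ccccc1)SCCCCCCNC(=O)c1cc(-c2ccncc2)n[nH]1`) gives 24700 nM and these two values lie within the usual scatter of each other. Among the compounds with values here, compound 2 therefore stands with compound 1 on the numbers so far. Compound 3 (`CC(C)C(=O)SCCCCCCNC(=O)c1cc(-c2ccncc2)n[nH]1`) has isopropyl in place of benzyloxy on a carbonyl carbon. Within the data shown here, no measured step informs this change, so nothing beyond the scatter is expected in this assay and the estimated 1.6-fold lower number from compound 2 to compound 3 (0.22 log units; within the scatter) stays within it. Compound 3 is estimated at 15000 nM with an expected range of 5000 nM to 40000 nM in this series.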

Compound 3, concentration for 50% growth inhibition: > 50000 nM
Compound 3 gave a limit, no number; the forecaster's own chance of this, stated with the estimate: 10%; at least 3.3-fold (0.52 log units) between middle value and limit.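

In this assay compound 3 gives a limit and not a number: > 50000 nM. Isopropyl in place of benzyloxy on a carbonyl carbon whose other neighbour is sulfur gives an at least 2.0-fold higher number from compound 2 to compound 3 (0.30 log units; that floor lies within the scatter), the first step read at this position, and it fixes only a floor. As far as these compounds go, the size of the step stays unknown because it rests on a limit: the limit of > 50000 nM in this assay, at which 1 of the 3 values shown sits.

From the compounds shown here alone, whether the six-membered aromatic ring or the oxygen of benzyloxy carries any of the difference stays open. So does the reading for an amine, a carboxylic acid or a longer carbon chain on this carbonyl carbon.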